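The source may report more compounds than this note shows. Statements on the series, on what has been measured and on what is new or still open speak of the compounds shown alone.

Compound 1, `CCCCCCCCCCCCCCCCCC(=O)Nc1nnc(S[C@@H]2O[C@H](COC(C)=O)[C@H](OC(C)=O)[C@H](OC(C)=O)[C@H]2OC(C)=O)s1`, and compound 2, `CCCCCCCCCCCCCCCCCC(=O)Nc1nnc(S[C@@H]2O[C@H](CO)[C@H](O)[C@H](O)[C@H]2O)s1`, share the same long saturated amide chain on the shared core and differ only in the groups on the rest of the molecule. In an ADME assay on CHO-K1 cells (Cricetulus griseus) for cytotoxicity, read by MTT assay, with a stated time of 24 h (on this read-out lower numbers stand for stronger inhibition and higher numbers for weaker inhibition), compound 1 gives 44700 nM. In this assay compound 2 is reported as "not active" (no number reported), so no number exists for it. Compound 3, `C=CCCCCCCCCC(=O)Nc1nnc(S[C@@H]2O[C@H](CO)[C@H](O)[C@H](O)[C@H]2O)s1`, keeps the unprotected core of compound 2 but has a shorter chain ending in a double bond; in this assay compound 3 is likewise reported as "not active" (no number reported), again without a number. Going by the values given here, compound 3 therefore stands among the two entries that give no single value; the only number at all in this set belongs to compound 1.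

Compound 4, `CCCCCCCC/C=C\CCCCCCCC(=O)Nc1nnc(S[C@@H]2O[C@H](CO)[C@H](O)[C@H](O)[C@H]2O)s1`, differs from compound 3 in one place: dec-1-en-1-yl in place of allyl on a saturated chain carbon, seven bonds along the chain from a carbonyl carbon. Among the compounds with values here, no measured pair in this set shows what such a lengthening of the chain does. Compound 2 already shows "not active" (no number reported) with a long chain on the same unprotected core, so little change beyond the usual scatter is expected in this assay, and the most likely outcome is again a report without a number. As a rough figure, compound 4 is expected near 100000 nM, within 30000 nM to 300000 nM.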

Compound 4, half-maximal inhibitory concentration: "not active" (no number reported)
Compound 4 has no reported number here, so the estimate cannot be set against anything.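

In this assay compound 3 and compound 4 are both reported as "not active" with no number, so no step can be read between them. The compounds shown leave open whether dec-1-en-1-yl in place of allyl changes anything on this read-out. Nothing shown here bears on this result.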